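Working notes: propyl in place of isopropyl

A few compounds are considered here, and "the series" means these few. Any claim that something is new, unique, unknown or untested is made for them only; others in the source may bear on it.

Readings so far in a functional assay on HCT-116 cells (Homo sapiens) for cytotoxicity, read by MTT assay, with a stated time of 48 h, in the presence of a further agent that is not named here; on this read-out higher numbers stand for an effect only at larger amounts of compound and lower numbers for an effect already at smaller amounts
- compound 1 `Cn1nc(C(F)(F)F)c2c(-c3ccccc3)cc(NNC(=O)Nc3cc(Cl)nc(Cl)c3)nc21` gives 18100 nM
- compound 2 `CC(C)c1cc(NNC(=O)Nc2cc(Cl)nc(Cl)c2)nc2c1c(C(F)(F)F)nn2C` gives 27200 nM
- compound 3 `CC(C)c1cc(NNC(=O)Nc2cc(Cl)nc(Cl)c2)nc2c1cnn2C` gives 17200 nM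

Compound 2 sits within the scatter of both compound 1 and compound 3, so these readings give no order among the three. The next compound, compound 4 `CCCc1cc(NNC(=O)Nc2cc(Cl)nc(Cl)c2)nc2c1c(C(F)(F)F)nn2C`, differs from compound 2 by propyl in place of isopropyl on an aromatic carbon (propyl in place of isopropyl on an aromatic carbon, opposite the ring nitrogen). The two have the same atoms, joined differently.

Among the measured compounds shown here, two measured steps bear on this change. The closer one is a 1.5-fold higher number from compound 1 to compound 2 (0.18 log units; within the scatter) with isopropyl in place of phenyl on that same aromatic carbon. The other is a 1.6-fold lower number from compound 2 to compound 3 (0.20 log units; within the scatter) with hydrogen in place of trifluoromethyl on a different aromatic carbon. Neither step leaves the scatter, and neither involves propyl, so the data hold no direct reading of this change. No step beyond the scatter is expected in this assay in either direction. The estimated step is a 1.2-fold lower number from compound 2 to compound 4 (0.07 log units; within the scatter) and it is expected to stay within the scatter. The value expected for compound 4 is 23000 nM (estimated range 12000 nM to 42000 nM).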

Compound 4, half-maximal effective concentration: 38200 nM
The estimate for compound 4 lay 1.7-fold (0.22 log units) below the measured number; the measured number falls inside the stated range.
By their numbers in this assay, from the lowest: compounds 3, 1, 2 and 4 (each within the scatter of the next, the first and the last beyond it).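

In this assay propyl in place of isopropyl on this aromatic carbon gives a 1.4-fold higher number from compound 2 to compound 4 (0.15 log units; within the scatter), so rejoining the same three carbons does not separate the two compounds in this read-out. Propyl in place of phenyl at the same carbon gives a 2.1-fold higher number from compound 1 to compound 4 (0.32 log units; beyond the scatter), a modest step and the first at this position to leave the scatter, whereas isopropyl in place of phenyl gives a 1.5-fold higher number from compound 1 to compound 2 (0.18 log units; within the scatter) and stays within it. No measurement on hand offers an explanation for either step.

Going by these compounds, the position has been read here only with phenyl, isopropyl and propyl, so it remains open whether a longer chain such as butyl, an amine or a carboxylic acid on this carbon would give a step clearly beyond the scatter. Propyl has also been read only with trifluoromethyl on the core, leaving open whether the same reading would hold for a propyl compound with hydrogen in place of trifluoromethyl.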